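Removing one fluoro from the 3,4-difluorophenyl group

This account rests on a few compounds, and the source may have more. Where it says the series, first, only, none or still open, it means among the compounds named here.

In an ADME assay on microsomes from liver (Homo sapiens) for metabolic stability (on this read-out lower numbers stand for slow clearance and higher numbers for fast clearance), compound 1 `O=C(CCCN1CCCCCC1)Nc1cnc(-c2ccc(F)cc2F)s1` gives 42 mL.min-1.g-1 and compound 2 `O=C(CCCN1CCCCCC1)Nc1cnc(-c2ccc(F)c(F)c2)s1` gives 42 mL.min-1.g-1 as well, so the two stand level. Compound 3 `O=C(CCCN1CCCCCC1)Nc1cnc(-c2ccc(F)cc2)s1` differs from compound 2 by a single edit: hydrogen in place of fluoro on an aromatic carbon and so carries hydrogen in place of fluoro on an aromatic carbon, turning 3,4-difluorophenyl into 4-fluorophenyl. Among the compounds with values here, only one measured step bears on this: no change at the digits printed from compound 1 to compound 2 (within the scatter) with 3,4-difluorophenyl in place of 2,4-difluorophenyl. Within the data shown here, that step changes where a fluoro sits rather than removing one, so it is only a loose guide, and no measured pair shows a fluoro being removed. Starting from compound 2 at 42 mL.min-1.g-1 no shift beyond the scatter is expected in either direction in this assay and no change at the digits printed from compound 2 to compound 3 (within the scatter) is the estimated step. For compound 3 the estimated clearance is 42 mL.min-1.g-1 with an expected range from 22 mL.min-1.g-1 to 78 mL.min-1.g-1 in this measurement.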

Compound 3, intrinsic clearance in microsomes in the Homo sapiens assay: 29 mL.min-1.g-1
The estimate for compound 3 lay 1.4-fold (0.16 log units) above the measured number; measured number inside the range.
By their numbers in the Homo sapiens assay, from the lowest: compounds 3, 1 and 2 (each within the scatter of the next).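

Unlike the earlier pair, where a fluoro only changed place, here one is removed, and in the Homo sapiens assay that gives a 1.4-fold lower number from compound 2 to compound 3 (0.16 log units; within the scatter) and a 1.4-fold lower number from compound 1 to compound 3 (0.16 log units; within the scatter), so for these compounds clearance does not depend on the second fluoro beyond the scatter. In a physicochemical assay for solubility, measured as kinetic solubility (a lower number here means a less soluble compound, a higher number a more soluble compound), compound 2 gives > 94 ug/mL, which is a limit of the assay and not a number. In the physicochemical assay compound 3 gives > 97 ug/mL, which is also a limit.

Going by these compounds, the step between these two limits cannot be read, so what this change does in the physicochemical assay stays open. Also open, on these data alone, is whether a methoxy group, a nitrile or an amine on this aromatic carbon, rather than fluoro or hydrogen, would move the number in the Homo sapiens assay beyond the scatter.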